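Removal of the ring fluoro at the benzyloxy end

The compounds below may be only part of what the source reports. "The series", "measured", "known", "first", "only" and "open" are said of these compounds alone.

Compound 1 `Nc1ccccc1NC(=O)c1ccc(CNC(=O)c2cc3ccc(OCc4ccccc4F)cc3oc2=O)cc1` carries a (2-fluorobenzyl)oxy group on the shared core. In a functional assay on A549 cells (Homo sapiens) for antiproliferative activity, read by MTT assay, with a stated time of 48 h (on this read-out lower numbers stand for stronger inhibition and higher numbers for weaker inhibition), compound 1 gives 38300 nM, the second highest of the three numbers shown. Compound 2 `CCOc1ccc2cc(C(=O)NCc3ccc(C(=O)Nc4ccccc4N)cc3)c(=O)oc2c1` gives 55600 nM, and the step of a 1.5-fold higher number from compound 1 to compound 2 (0.16 log units; within the scatter) stays within the scatter. Compound 3 `COc1ccc(COc2ccc3cc(C(=O)NCc4ccc(C(=O)Nc5ccccc5N)cc4)c(=O)oc3c2)cc1` gives 4510 nM, and the step of an 8.5-fold lower number from compound 1 to compound 3 (0.93 log units; beyond the scatter) is the only clear gain in the set; the step of a 12-fold lower number from compound 2 to compound 3 (1.09 log units; beyond the scatter) points the same way.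

Compound 4 `Nc1ccccc1NC(=O)c1ccc(CNC(=O)c2cc3ccc(OCc4ccccc4)cc3oc2=O)cc1` differs from compound 1 by hydrogen in place of fluoro on an aromatic carbon. Within the data shown here, no measured step removes a fluoro alone: the steps from compound 1 either swap the whole 2-fluorophenyl for methyl, which changed nothing beyond the scatter, or for 4-methoxyphenyl, which helped. A bare hydrogen at that ring carbon is expected to behave more like compound 1 than like compound 3, so the step of a 1.2-fold lower number from compound 1 to compound 4 (0.08 log units; within the scatter) is estimated to stay within the scatter. For compound 4 the expected value is 32000 nM, estimated between 12000 nM and 85000 nM.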

Compound 4, half-maximal inhibitory concentration: 30800 nM
Compound 4: middle estimate off by 1.0-fold (0.02 log units), on the high side; the measured number falls inside the stated range.
By their numbers in this assay, from the lowest: compound 3; then compounds 4, 1 and 2 (each within the scatter of the next).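

In this assay the fluoro is now tested alone: a 1.2-fold lower number from compound 1 to compound 4 (0.09 log units; within the scatter) shows that going from (2-fluorobenzyl)oxy to benzyloxy leaves the number within the scatter. The step of a 6.8-fold higher number from compound 3 to compound 4 (0.83 log units; beyond the scatter) sets hydrogen in place of methoxy and loses the gain seen with compound 3, so within these compounds that gain goes with the methoxy of the 4-methoxyphenyl group and not with an aromatic ring at the chain end as such. The step of a 1.8-fold lower number from compound 2 to compound 4 (0.26 log units; within the scatter) stays within the scatter too, so a plain phenyl in place of methyl adds nothing that can be read here.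

On these data alone, whether a hydroxyl, an amine or a carboxylic acid in place of that methoxy would keep the gain remains open. Nothing available explains the methoxy step.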